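Series notes: sulfonyl for acyl on the amine nitrogen

The source may report more compounds than this note shows. Statements on the series, on what has been measured and on what is new or still open speak of the compounds shown alone.

Compound 3 `CCCCCCCCCCCCNC(=O)[C@@H](NC(=O)/C=C/c1ccccc1)[C@@H](C)O` gives 200000 nM in a functional assay on SW-620 cells (Homo sapiens) for cytotoxicity, read by MTT assay, with a stated time of 48 h; on this read-out lower numbers stand for stronger inhibition and higher numbers for weaker inhibition. Compound 1 `CCCCCCCCCCCCNC(=O)[C@@H](NC(=O)c1ccccc1)[C@@H](C)O` gives 200000 nM in this assay, so compound 3 stands level with compound 1: no change at the digits printed from compound 1 to compound 3 (within the scatter). Compound 2 `CCCCCCCCCCCCNC(=O)[C@@H](NC(=O)c1cc2ccccc2n1C)[C@@H](C)O` reaches only a limit of the assay, > 200000 nM in this assay. That limit is the limit of > 200000 nM in this assay, at which 1 of the 3 values shown sits. Compound 4 `CCCCCCCCCCCCNC(=O)[C@@H](NS(=O)(=O)c1ccc(C)cc1)[C@@H](C)O` is not yet measured; it differs from compound 3 by (4-methylphenyl)sulfonyl in place of (2-phenylethenyl)carbonyl on an amine nitrogen. Going by the values given here, no measured step swaps an acyl group for a sulfonyl; the nearest are no change at the digits printed from compound 1 to compound 3 (within the scatter) and a number no lower from compound 1 to compound 2 (the limit leaves the size open), both swaps on the carbonyl carbon, one within the scatter, the other a limit of open size. The expected step is no change at the digits printed from compound 3 to compound 4 (within the scatter), with a fair chance that only a limit is reported. Compound 4 is estimated at 200000 nM, range 100000 nM to 400000 nM in this assay.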

Compound 4, half-maximal inhibitory concentration: 25600 nM
Compound 4: middle estimate off by 7.8-fold (0.89 log units), on the high side; the whole stated range lies above it.
By their numbers in this assay, from the lowest: compound 4; then compounds 1 and 3 (each within the scatter of the next).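

On the amine nitrogen, a sulfonyl in place of an acyl group moves the number in this assay: a 7.8-fold lower number from compound 3 to compound 4 (0.89 log units; beyond the scatter), and a 7.8-fold lower number from compound 1 to compound 4 (0.89 log units; beyond the scatter). Among the acyl compounds, compound 1 and compound 3 show no difference at the digits printed, so this is the first step shown that lies beyond the scatter. Compound 2 gives only a limit of the assay: the limit of > 200000 nM in this assay, at which 1 of the 4 values shown sits.

The compounds shown do not separate the sulfonyl link from its 4-methylphenyl group. Phenylsulfonyl and methylsulfonyl on the same nitrogen remain open, as does a shorter chain on the amide.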